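A few compounds are considered here, and "the series" means these few. Any claim that something is new, unique, unknown or untested is made for them only; others in the source may bear on it.

Going by the values given here, compound 3 (`CCN(CC)CCCC(C)Nc1ccnc(COc2ccccc2Cl)c1`) is the only compound of the three measured that gives a number rather than a limit: in an assay on isolated protein for inhibition of C-C chemokine receptor type 4 (Homo sapiens) (a lower number here means a stronger inhibitor, a higher number a weaker inhibitor), compound 3 gives 17000 nM. Compound 1 (`CCN(CC)CCCC(C)Nc1nc(CCCc2ccccc2)nc2ccccc12`) reaches only a limit of the assay, as in this assay compound 1 gives > 10000 nM. Compound 2 (`CCN(CC)CCCC(C)Nc1nc(C(=O)Nc2ccccc2)nc2ccccc12`) likewise sits at a limit, since in this assay compound 2 gives > 10000 nM. Among the compounds with values here, the one step between measured compounds, a step that the two limits leave unreadable from compound 1 to compound 2, cannot be read in size, owing to the limit of > 10000 nM in this assay, at which 2 of the 3 values shown sit.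

Compound 4 (`CCN(CC)CCCC(C)Nc1ccnc(COc2ccc(Cl)cc2)c1`) differs from compound 3 in one place: 4-chlorophenyl in place of 2-chlorophenyl on an oxygen on a saturated carbon. Within the data shown here, no measured step touches this part of the molecule, and the only readable step gives no direction for it. The expectation is therefore a step of no size beyond the scatter, no change at the digits printed from compound 3 to compound 4 (within the scatter), in this assay. Compound 4 is estimated at 17000 nM in this assay, with a range from 5000 nM to 60000 nM.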

Compound 4, half-maximal inhibitory concentration: 20000 nM
For compound 4 the middle estimate is 1.2-fold (0.07 log units) below the measured one; measured number inside the range.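

Going by these compounds alone, compound 4 provides the first step that can be read as a size: in this assay, 4-chlorophenyl in place of 2-chlorophenyl on an oxygen on a saturated carbon gives a 1.2-fold higher number from compound 3 to compound 4 (0.07 log units; within the scatter). For this pair, then, where the chlorine stands on the phenyl ring does not separate the two compounds beyond the scatter, something the limits of the earlier pair could not show for any change. No measured property available here bears on this result.

From the compounds shown here alone, whether a 3-chlorophenyl or an unsubstituted phenyl would read the same at this position remains open. So does the effect of replacing the chlorine with a methoxy group, an amine or a carboxylic acid, or of replacing the oxygen that links the ring to the saturated carbon with a longer chain.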